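Swapping a nitrile tail for an allyl tail

The source may hold more compounds than are shown below. What is called first, only, known or untested is meant among the compounds shown, and "the series" means these compounds.

Compound 1 `C=CCc1cc(C(C)=O)c(O)cc1OCCCC#N` and compound 2 `CCc1cc(C(C)=O)c(O)cc1OCCCC(C)(C)c1nnn[nH]1` share a core and differ in more than one place. In an assay on isolated protein for inhibition of leukotriene B4 receptor 1 (Homo sapiens), tested at 10 uM (a lower number here means less inhibition, a higher number more inhibition at the concentration tested (going by the name of the read-out)), compound 1 gives 47%, the lower of the two numbers; compound 2 gives 100%, a gap beyond the usual scatter. Compound 3 `C=CCCCCOc1cc(O)c(C(C)=O)cc1CC=C` is the untested partner of compound 1, differing by allyl in place of cyano on a saturated chain carbon, three bonds along the chain from an oxygen on an aromatic ring. Going by the values given here, no measured pair shows what this exchange alone does, so only a small step from compound 1 to compound 3 is expected, a number 2 percentage points lower from compound 1 to compound 3 (within the scatter), in no firm direction. Compound 3 is accordingly estimated at 45% in this assay, with a plausible span from 20% to 75%.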

Compound 3, a percentage reported as inhibition, at one concentration (the size of the read-out at that concentration, not a potency): 73%
The estimate for compound 3 lay 28 percentage points below the measured number, within the range that was stated.
By their numbers in this assay, from the lowest: compound 1; then compound 3; then compound 2.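

In this assay, going by these compounds alone, the step of a number 26 percentage points higher from compound 1 to compound 3 (beyond the scatter) gives the first reading of a change in one place, allyl in place of cyano on a saturated chain carbon. It shows that this place on the chain affects the read-out, and that the nitrile is not needed for inhibition at the concentration tested. Nothing measured explains the gain.

On these data alone, whether a carboxylic acid, an amine or a longer chain at this place would give more or less inhibition stays open. Compound 2 differs from compound 3 in more than one place, so that pair cannot settle it.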